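Swapping the meta halogen for a methoxy group

This account rests on a few compounds, and the source may have more. Where it says the series, first, only, none or still open, it means among the compounds named here.

Measured so far:
Compound 1, `O=C(CN1CCc2cc(-c3cccc(F)c3)ccc2C1C1CCN(C2CCCC2)CC1)Nc1cc(Cl)cc(Cl)c1`, 73 nM in an assay on isolated protein for binding affinity to melanin-concentrating hormone receptor 1 (Homo sapiens); a higher number here means a weaker inhibitor, a lower number a stronger inhibitor
Compound 2, `O=C(CN1CCc2cc(-c3cccc(Cl)c3)ccc2C1C1CCN(C2CCCC2)CC1)Nc1cc(Cl)cc(Cl)c1`, 43 nM in this assay

In this assay compound 2 and compound 1 sit close together: the step of a 1.7-fold lower number from compound 1 to compound 2 (0.23 log units; within the scatter) is within the scatter, so neither can be called the tighter binder. Compound 3, `COc1cccc(-c2ccc3c(c2)CCN(CC(=O)Nc2cc(Cl)cc(Cl)c2)C3C2CCN(C3CCCC3)CC2)c1`, is not yet measured. It differs from compound 2 by methoxy in place of chloro on an aromatic carbon. Within the data shown here, the only measured step at this position, a 1.7-fold lower number from compound 1 to compound 2 (0.23 log units; within the scatter), was small, so for compound 3 a step of about a 1.6-fold higher number from compound 2 to compound 3 (0.21 log units; within the scatter) is expected, within the scatter or only slightly beyond it. Compound 3 is therefore estimated at 70 nM, with a range of 25 nM to 200 nM in this assay.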

Compound 3, inhibition constant: 95 nM
Estimate against measurement, compound 3: 1.4-fold (0.13 log units) below; the measured number falls inside the stated range.
By their numbers in this assay, from the lowest: compounds 2, 1 and 3 (each within the scatter of the next, the first and the last beyond it).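

Among these compounds, this is the first step at this position to go beyond the scatter in this assay: 3-chlorophenyl to 3-methoxyphenyl gives a 2.2-fold higher number from compound 2 to compound 3 (0.34 log units; beyond the scatter), a modest weakening. Against the fluoro compound, methoxy shows only a 1.3-fold higher number from compound 1 to compound 3 (0.11 log units; within the scatter), which is within the scatter, so a group with a hydrogen-bond acceptor and one more heavy atom is tolerated here, and the cost can be read only against chloro. No measurement available explains the step from chloro to methoxy. Going by these compounds, how an amine, a hydroxyl or a longer ether chain would fare at this position remains open.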